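From Dimethylamino to 4-Propylcyclohexyl: One Substituent Swap

The compounds below may be only part of what the source reports. "The series", "measured", "known", "first", "only" and "open" are said of these compounds alone.

In a functional assay on KB-V1 cells (Homo sapiens) for cytotoxicity, read by MTT assay, with a stated time of 72 h (on this read-out lower numbers stand for stronger inhibition and higher numbers for weaker inhibition), three compounds built on one shared core have been measured so far. Compound 1 `C=CCNC(=S)N/N=C1\C(=O)Nc2ccccc21` gives 20700 nM and compound 2 `COc1cc(NC(=S)N/N=C2\C(=O)Nc3ccccc32)cc(OC)c1OC` gives 3490 nM in this test. Compound 3 `CN(C)c1ccc(NC(=S)N/N=C2\C(=O)Nc3ccccc32)cc1` gives 2320 nM and sits at the low end of the three numbers, level with compound 2 within the usual scatter of repeated measurements and well beyond that scatter from compound 1.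

The next compound, compound 4 `CCCC1CCC(c2ccc(NC(=S)N/N=C3\C(=O)Nc4ccccc43)cc2)CC1`, has not yet been measured. It carries 4-propylcyclohexyl in place of dimethylamino on an aromatic carbon and keeps the rest of compound 3 unchanged. Going by the values given here, no measured pair differs in just one place, so the data offer no direct guide to this swap. They do show that compound 2 (3490 nM) and compound 3 (2320 nM) carry different groups yet stay within the scatter of each other, which points to a modest change here. The step expected in this assay is a 1.5-fold lower number from compound 3 to compound 4 (0.19 log units; within the scatter) and it is expected to be slightly downward and to stay within the scatter. For compound 4 the estimated value is 1500 nM with an expected range from 400 nM to 6000 nM in this estimate.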

Compound 4, half-maximal inhibitory concentration: 11000 nM
Beside the measured number, compound 4's estimate is 7.3-fold (0.87 log units) below it; the measured number lies above the stated range.
By their numbers in this assay, from the lowest: compounds 3 and 2 (each within the scatter of the next); then compounds 4 and 1 (each within the scatter of the next).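

In this assay, going by these compounds alone, the swap of dimethylamino for 4-propylcyclohexyl gives the first comparison in this set between two compounds that differ in only one place, and it reads as a 4.7-fold higher number from compound 3 to compound 4 (0.68 log units; beyond the scatter). The earlier compounds shown here differed in more than one place, so they could not show that this position on the aromatic ring responds to what it carries: here, a change of group alone moves the number beyond the usual scatter, and the direction is toward weaker inhibition. This single swap removes the nitrogen and adds a six-membered non-aromatic ring of carbon only together with a propyl chain, and nothing measured here separates the contributions of these changes or explains the rise.

It remains open which part of the larger group accounts for the step, and a cyclohexyl ring without the propyl chain would be one way to divide the change. On these data alone, it is equally open whether a straight butyl chain or a morpholine ring at this same place would give a number closer to that of compound 3 or to that of compound 4.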